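This account rests on a few compounds, and the source may have more. Where it says the series, first, only, none or still open, it means among the compounds named here.

Working notes on the series. In a functional assay on SK-OV-3 cells (Homo sapiens) for inhibition, read by sulforhodamine B assay, with a stated time of 48 h (a higher number here means a weaker inhibitor of growth, a lower number a stronger inhibitor of growth), compound 1 (`Cc1nnc(-c2nn(-c3ccccc3)c(-c3ccccc3)c2C#N)c2cn(-c3ccccc3)nc12`) gives 36800 nM. Compound 2 (`N#Cc1c(-c2nnc(-c3nn(-c4ccccc4)c(-c4ccccc4)c3C#N)c3nn(-c4ccc(Cl)cc4)cc23)nn(-c2ccccc2)c1-c1ccccc1`) gives 36800 nM, which leaves the two level within the scatter. Within the data shown here, no step between measured compounds that differ in one place is available, so the size of the next change has no direct calibration. Compound 3 (`N#Cc1c(-c2nnc(-c3ccccc3)c3nn(-c4ccccc4)cc23)nn(-c2ccccc2)c1-c1ccccc1`) departs from compound 1 at one position, with phenyl in place of methyl on an aromatic carbon. The swap sits on a six-membered aromatic ring with 2 nitrogen, para to a large group. With compound 1 at 36800 nM as the only starting point, no step beyond the scatter is expected in this assay. The expected result is a 1.2-fold lower number from compound 1 to compound 3 (0.09 log units; within the scatter). For compound 3 the estimated value is 30000 nM, with an expected range of 12000 nM to 70000 nM.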

Compound 3, concentration for 50% growth inhibition: 32800 nM
The estimate for compound 3 lay 1.1-fold (0.04 log units) below the measured number; the range from low to high includes it.
By their numbers in this assay, from the lowest: compounds 3, 1 and 2 (each within the scatter of the next).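

Among these compounds, this is the first one-place step: in this assay, phenyl in place of methyl on an aromatic carbon gives a 1.1-fold lower number from compound 1 to compound 3 (0.05 log units; within the scatter). At this position, on a six-membered aromatic ring with 2 nitrogen and para to a large group, a six-membered aromatic ring of carbon only can therefore stand where no ring stood without the number separating the two compounds. No measurement on hand bears on why the two groups read alike.

On these data alone, neither group carries a hydrogen-bond donor or acceptor, so it remains open whether an amine or a carboxylic acid at this position would read differently. It also remains open whether any replacement here can produce a step beyond the scatter, since methyl and phenyl are the only two groups shown at this position.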